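This account rests on a few compounds, and the source may have more. Where it says the series, first, only, none or still open, it means among the compounds named here.

Measured so far:
compound 1, `Cc1ccc(OCC(=O)N(Cc2cccs2)c2ccccn2)cc1`: 200 nM
compound 2, `CCN(Cc1cccs1)C(=O)COc1ccc2c(c1)COC2`: 61 nM

In an assay on HEK293 cells for agonist activity at transient receptor potential cation channel subfamily M member 8 (Homo sapiens), read by fluorescence and calcium flux, with a stated time of 15 min (on this read-out higher numbers stand for an effect only at larger amounts of compound and lower numbers for an effect already at smaller amounts), compound 1 gives 200 nM, the higher of the two numbers in hand; compound 2 shows the lower number, and the gap between them is beyond the usual scatter. Compound 3, `Cc1ccc(OCC(=O)N(Cc2cccs2)c2ccccc2)cc1`, has not been measured. Its change from compound 1: phenyl in place of pyridin-2-yl on an amide-type nitrogen. For the measured compounds named here, no measured pair carries this change, so the expectation rests on compound 1 alone; a step of a 1.3-fold higher number from compound 1 to compound 3 (0.10 log units; within the scatter) is expected, small and within the scatter, with no clear direction. Compound 3 is therefore estimated at 250 nM, range 80 nM to 800 nM.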

Compound 3, half-maximal effective concentration: 23 nM
Compound 3: middle estimate off by 11-fold (1.04 log units), on the high side; measured number below the stated range.
By their numbers in this assay, from the lowest: compound 3; then compound 2; then compound 1.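

Phenyl in place of pyridin-2-yl on an amide-type nitrogen gives an 8.7-fold lower number from compound 1 to compound 3 (0.94 log units; beyond the scatter), so the group at this position changes the number beyond the scatter while the rest of compound 1 stays the same. The groups have the same heavy-atom count, and pyridin-2-yl differs by its ring nitrogen and hydrogen-bond acceptor. Nothing available explains the direction or size of this step.

Whether the ring nitrogen itself accounts for the step remains open, since pyridin-3-yl is not among the compounds shown. As far as these compounds go, how a fluorine or methoxy group on the phenyl of compound 3 would read is also open.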